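This account rests on a few compounds, and the source may have more. Where it says the series, first, only, none or still open, it means among the compounds named here.

Measured in a functional assay on KG-1 cells (Homo sapiens) for cytotoxicity, read by luminescence and CellTiter-Glo, with a stated time of 3 days; on this read-out lower numbers stand for stronger inhibition and higher numbers for weaker inhibition:
- compound 1 `COc1ccc(O)c(C(=O)Nc2ccc(C#N)cc2)c1`: > 10000 nM
- compound 2 `N#Cc1ccc(NC(=O)c2ccc(Cl)cc2O)cc1`: 1920 nM
- compound 3 `COc1ccc(C(=O)Nc2ccc(C#N)cc2)c(O)c1`: 5430 nM

Compound 1 gives only a limit, not a number: the limit of > 10000 nM in this assay, at which 1 of the 3 values shown sits.

Compound 4 `N#Cc1ccc(NC(=O)c2cc(C(F)(F)F)ccc2O)cc1` has not yet been measured. It carries trifluoromethyl in place of methoxy on an aromatic carbon of compound 1 (trifluoromethyl in place of methoxy on an aromatic carbon). The closest measured evidence is a 2.8-fold higher number from compound 2 to compound 3 (0.45 log units; beyond the scatter), a modest change on a different aromatic carbon, where methoxy took the place of chloro. Among the compounds with values here, no measured compound holds trifluoromethyl, so this is only a loose guide. Read in reverse, that step suggests that removing methoxy may give a lower number in this assay. The estimated change is an at least 4.0-fold lower number from compound 1 to compound 4 (0.60 log units; beyond the scatter). Compound 4 is estimated at 2500 nM, with an expected range from 700 nM to 9000 nM.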

Compound 4, half-maximal inhibitory concentration: 4810 nM
The estimate for compound 4 lay 1.9-fold (0.28 log units) below the measured number, and the stated range covers the measured number.
By their numbers in this assay, from the lowest: compound 2; then compounds 4 and 3 (each within the scatter of the next). At a limit, above all of these: compound 1.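

In this assay, trifluoromethyl in place of methoxy on the aromatic carbon para to a hydroxy group gives an at least 2.0-fold lower number from compound 1 to compound 4 (0.31 log units; beyond the scatter). Within the data shown here, this is the first measured step at this position, so it shows that the number here depends on the group the carbon carries, whereas the earlier step lay on a different aromatic carbon. The full size of the step cannot be read because compound 1 gives only a limit: the limit of > 10000 nM in this assay, at which 1 of the 4 values shown sits.

On these data alone, whether an amine or a carboxylic acid at this carbon would lower the number further remains open.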